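The compounds below may be only part of what the source reports. "The series", "measured", "known", "first", "only" and "open" are said of these compounds alone.

The measured compounds, each tested in a functional assay on MDA-MB-231 cells (Homo sapiens) for inhibition, read by MTT assay, with a stated time of 72 h; a lower number here means a stronger inhibitor, a higher number a weaker inhibitor:

compound 1, `O=C(CSc1nc(Nc2ccccc2)c2ccccc2n1)Nc1ccc(Cl)cc1`: compound 1 gives 17200 nM
compound 2, `O=C(CSc1nc(Nc2ccccc2)c2ccccc2n1)Nc1ccc(Br)cc1`: compound 2 gives 11500 nM
compound 3, `C=CC(=O)Nc1cccc(NC(=O)CSc2nc(Nc3ccc(Cl)cc3)c3ccccc3n2)c1`: compound 3 gives 10300 nM

Compounds 1 and 2 share one core and differ in a single place, (bromo in place of chloro on an aromatic carbon). In this assay this gave a 1.5-fold lower number from compound 1 to compound 2 (0.17 log units; within the scatter). Compound 3 carries a different core from compound 1; how the two cores differ is not broken down here. Its value in this assay lies within the scatter of both compound 1 and compound 2, so the three numbers cannot be told apart.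

Compound 4, `C=CC(=O)Nc1cccc(NC(=O)CSc2nc(Nc3ccc(Br)cc3)c3ccccc3n2)c1`, has not yet been measured. It differs from compound 3 by bromo in place of chloro on an aromatic carbon, the same change already seen from compound 1 to compound 2. Because that earlier step, a 1.5-fold lower number from compound 1 to compound 2 (0.17 log units; within the scatter), stayed within the scatter, a step of similar size is expected here: a 1.3-fold lower number from compound 3 to compound 4 (0.11 log units; within the scatter). Compound 4 is therefore estimated to give 8000 nM in this assay, with the number expected to fall between 4000 nM and 20000 nM.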

Compound 4, half-maximal inhibitory concentration: 17300 nM
Compound 4: middle estimate off by 2.2-fold (0.33 log units), on the low side; measured number inside the range.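

In this assay, the exchange of chloro for bromo on the core of compound 3 gave a 1.7-fold higher number from compound 3 to compound 4 (0.23 log units; within the scatter). Set beside the same exchange on the core of compound 1, the two steps cannot be told apart: the same change on two cores in this assay, a 1.5-fold lower number (0.17 log units; within the scatter) from compound 1 to compound 2 and a 1.7-fold higher number (0.23 log units; within the scatter) from compound 3 to compound 4, 2.5-fold (0.40 log units) apart, within the scatter of two such steps. This shows that, on both cores, the exchange left the number within the scatter, so the two steps are consistent with one small or absent effect, and neither can be given a real direction; it does not show that the exchange would carry over with a fixed size or sign, since two small steps are too little to establish that.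

As far as these compounds go, all four compounds carry only chloro or bromo at the exchanged place, so it remains open what fluoro, a methoxy group or an amine there would do in this assay. From the compounds shown here alone, it also remains open whether any such group would shift the number beyond the scatter on either core, which is what a real test of carrying a change between the cores would need.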